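The compounds below may be only part of what the source reports. "The series", "measured", "known", "first", "only" and "open" are said of these compounds alone.

Compound 3 `COc1ccc(NC(=O)Nc2cccc(CNc3ncnc4ccccc34)c2)cc1` is the starting point of this step. In a functional assay on HepG2 cells (Homo sapiens) for antiproliferative activity, read by MTT assay (on this read-out lower numbers stand for stronger inhibition and higher numbers for weaker inhibition), compound 3 gives > 50000 nM, which is a limit of the assay and not a number. Its two measured relatives stand the same way. Compound 1 `Cc1ccccc1NC(=O)Nc1cccc(CNc2ncnc3ccccc23)c1` gives in this assay > 50000 nM, again a limit. Compound 2 `Cc1ccc(NC(=O)Nc2cccc(CNc3ncnc4ccccc34)c2)cc1` gives in this assay > 50000 nM, once more a limit. All three values therefore sit at the limit of > 50000 nM in this assay, at which 3 of the 3 values shown sit. Consequently the steps a step that the two limits leave unreadable from compound 1 to compound 2, a step that the two limits leave unreadable from compound 1 to compound 3 and a step that the two limits leave unreadable from compound 2 to compound 3 cannot be read, and none of them tells how large a change of the group on the phenyl ring may be.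

The unmeasured compound 4 `CC(C)(C)c1ccc(NC(=O)Nc2cccc(CNc3ncnc4ccccc34)c2)cc1` differs from compound 3 by tert-butyl in place of methoxy on an aromatic carbon. No measured step bears on this exchange with a readable size; the only guidance is that every variation of this phenyl substituent shown so far has left the compound at the limit. Compound 4 is therefore expected to give in this assay about 60000 nM, within 20000 nM to 200000 nM. The expected step that the limit leaves unreadable from compound 3 to compound 4 is accordingly nothing beyond the scatter.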

Compound 4, half-maximal inhibitory concentration: 17000 nM
For compound 4 the middle estimate is 3.5-fold (0.55 log units) above the measured one; measured number below the stated range.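

In this assay, the group on this phenyl ring can move the read-out after all: tert-butyl in place of methoxy gives an at least 2.9-fold lower number from compound 3 to compound 4 (0.46 log units; beyond the scatter), and tert-butyl in place of methyl gives an at least 2.9-fold lower number from compound 2 to compound 4 (0.46 log units; beyond the scatter). The 4-(tert-butyl)phenyl group in place of 2-methylphenyl likewise gives an at least 2.9-fold lower number from compound 1 to compound 4 (0.46 log units; beyond the scatter), while the steps among compounds 1, 2 and 3 still cannot be read. Compound 4 is the only compound shown with a readable number, and the other three remain at a limit: the limit of > 50000 nM in this assay, at which 3 of the 4 values shown sit.

From the compounds shown here alone, how far each step really reaches stays open, as each starts from a limit. The compounds shown also leave open whether tert-butyl is unique here or whether an isopropyl, a cyclohexyl or a phenyl group at this place would lower the number as well.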